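Chain replacement on the amine of compound 1

A few compounds are considered here, and "the series" means these few. Any claim that something is new, unique, unknown or untested is made for them only; others in the source may bear on it.

Compound 1 `c1ccc2c(c1)CN[C@@H](CN(CCCCNCC1CCOCC1)[C@H]1CCCc3cccnc31)C2` gives 52.9 nM in a functional assay on cells for antagonist activity at C-X-C chemokine receptor type 4 (Homo sapiens), read by fluorescence and calcium flux, with stated times of 25 min and 90 s; a higher number here means a weaker inhibitor, a lower number a stronger inhibitor. Among the three measured compounds it has the lowest number; compound 3 `c1ccc2c(c1)CN[C@@H](CN(Cc1ccc(CNC3CCOCC3)cc1)[C@H]1CCCc3cccnc31)C2` gives 90.3 nM, a gap within the scatter, and compound 2 `FC1(F)CCC(NCc2ccc(CN(C[C@H]3Cc4ccccc4CN3)[C@H]3CCCc4cccnc43)cc2)CC1` gives 143 nM, a gap beyond it. Among the compounds with values here, the one measured step, a 1.6-fold lower number from compound 2 to compound 3 (0.20 log units; within the scatter), shows that exchanging one saturated six-membered ring with 1 hetero atom for another on the amine nitrogen moves the number only within the scatter.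

Compound 4 `C(=C/CN(C[C@H]1Cc2ccccc2CN1)[C@H]1CCCc2cccnc21)\CNCc1cccnc1` differs from compound 1 as follows: a group of 11 heavy atoms (9 carbon, 2 nitrogen; one six-membered aromatic ring with 1 hetero atom) in place of a group of 11 heavy atoms (9 carbon, 1 nitrogen, 1 oxygen; one six-membered non-aromatic ring with 1 hetero atom), on a saturated chain carbon bound to an amine nitrogen. Within the data shown here, no measured step covers a swap of a six-membered non-aromatic ring with 1 hetero atom for a six-membered aromatic ring with 1 hetero atom, nor the introduction of a double bond outside aromatic rings in the chain. Among the measured compounds shown here, the step from compound 2 to compound 3 is the only guide, and it was small. The change in compound 4 is expected to be modest, a 1.4-fold higher number from compound 1 to compound 4 (0.15 log units; within the scatter), with no firm direction. Compound 4 is therefore estimated at 75 nM, in the range 25 nM to 220 nM.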

Compound 4, half-maximal inhibitory concentration: 92.8 nM
Beside the measured number, compound 4's estimate is 1.2-fold (0.09 log units) below it, within the range that was stated.
By their numbers in this assay, from the lowest: compounds 1, 3, 4 and 2 (each within the scatter of the next, the first and the last beyond it).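

In this assay, a 1.8-fold higher number from compound 1 to compound 4 (0.24 log units; within the scatter). This step changes more than the earlier one, which exchanged one six-membered non-aromatic ring with 1 hetero atom for another: here a six-membered aromatic ring with 1 hetero atom and a double bond outside aromatic rings enter together on a saturated chain carbon bound to an amine nitrogen, and the number still stays within the scatter. No measurement offered here explains this result or bears on it.

The ring and the double bond enter in one step, so the contribution of each cannot be separated from these compounds. As far as these compounds go, how a carboxylic acid, an amide or a longer chain would read at this place remains open, and so does whether a phenyl ring would match the six-membered aromatic ring with 1 hetero atom.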